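The compounds below may be only part of what the source reports. "The series", "measured", "known", "first", "only" and "open" are said of these compounds alone.

Compound 1 `O=C(NCCCCc1ccccc1)c1cccc(C2SCC(=O)N2c2cccc(-c3c[nH]nn3)c2)c1`: 110 nM
Compound 2 `COc1ccccc1N1C(=O)C(C)SC1c1cccc(C(=O)NCCCCc2ccccc2)c1`: 45.1 nM
Compound 3 `CC1SC(c2cccc(C(=O)NCCCCc3ccc(Cl)cc3)c2)N(c2cccc(C3CC3)c2)C1=O`: 932 nM

All three were tested in a functional assay on HOS-TE85 cells (Homo sapiens) for inhibition, read by CCK-8 assay, with a stated time of 72 h; on this read-out lower numbers stand for stronger inhibition and higher numbers for weaker inhibition. Compound 1 stands second highest of the three numbers: compound 2 gives a lower number, a gap beyond the usual scatter, and compound 3 gives a higher number, a gap also beyond the scatter. Compound 4 `COc1ccc(F)cc1N1C(=O)CSC1c1cccc(C(=O)NCCCCc2ccccc2)c1` has not yet been measured. It differs from compound 1 in a single place: a group of 9 heavy atoms (7 carbon, 1 oxygen, 1 fluorine; one six-membered aromatic ring of carbon only) in place of a group of 11 heavy atoms (8 carbon, 3 nitrogen; one five-membered aromatic ring with 3 hetero atoms, one six-membered aromatic ring of carbon only), on an amide-type nitrogen in a ring. Among the measured compounds shown here, no measured pair shows this exact change, so its size can only be guessed from the spread of the three numbers, with compound 2 and its value of 45.1 nM as the closest point of comparison. The step expected in this assay is a 1.6-fold lower number from compound 1 to compound 4 (0.20 log units; within the scatter), toward a lower number. Compound 4 is therefore estimated at 70 nM, with a likely range from 25 nM to 250 nM.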

Compound 4, half-maximal inhibitory concentration in the HOS-TE85 assay: 8.8 nM
Compound 4: the middle estimate sits 8.0-fold (0.90 log units) above what was measured; measured number outside the range, below it.
By their numbers in the HOS-TE85 assay, from the lowest: compound 4; then compound 2; then compound 1; then compound 3.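

Putting 5-fluoro-2-methoxyphenyl in place of the triazole-bearing group on the amide-type nitrogen in a ring gives, in the HOS-TE85 assay, a 13-fold lower number from compound 1 to compound 4 (1.10 log units; beyond the scatter), the first step showing that this single position can move the number strongly. In a physicochemical assay for solubility, read by turbidimetry, measured as kinetic solubility, at pH 6.8 (a higher number here means a more soluble compound, a lower number a less soluble compound), compound 1 gives 20000 nM and compound 4 gives 10000 nM, two values within the usual scatter of each other. Nothing measured here explains the step. From the compounds shown here alone, compound 4 carries its methoxy and fluorine together, so their separate shares stay open. Going by these compounds, how an unsubstituted phenyl or a pyridine ring would read at this position also stays open.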